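The source may report more compounds than this note shows. Statements on the series, on what has been measured and on what is new or still open speak of the compounds shown alone.

Measured compounds:
compound 1, `N#Cc1ccccc1CN1CCc2c(sc(NC(=O)c3ccccc3Cl)c2C(N)=O)C1`, 9500 nM
compound 2, `NC(=O)c1c(NC(=O)c2ccc(C(F)(F)F)cc2)sc2c1CCN(Cc1ccc(Cl)cc1Cl)C2`, 10900 nM
compound 3, `NC(=O)c1c(NC(=O)c2cccc([N+](=O)[O-])c2)sc2c1CCN(Cc1ccc(Cl)cc1Cl)C2`, 16500 nM

In a functional assay on MKN-74 cells (Homo sapiens) for antiproliferative activity, with a stated time of 24 h (a lower number here means a stronger inhibitor, a higher number a weaker inhibitor), compound 1 gives the lowest of the three numbers, but its gaps to compound 2 and to compound 3 both lie within the usual scatter, so no order among the three can be claimed. Compound 4, `COc1ccccc1NC(=S)N1CCc2c(sc(NC(=O)c3ccccc3Cl)c2C(N)=O)C1`, has not been measured in this assay. It differs from compound 1 in one place: a group of 11 heavy atoms (8 carbon, 1 nitrogen, 1 oxygen, 1 sulfur; one six-membered aromatic ring of carbon only) in place of a group of 9 heavy atoms (8 carbon, 1 nitrogen; one six-membered aromatic ring of carbon only), on an amine nitrogen in a ring.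

For the measured compounds named here, only one measured step exists, a 1.5-fold higher number from compound 2 to compound 3 (0.18 log units; within the scatter), and it changes the group on a carbonyl carbon, not the group on the amine nitrogen in a ring where compound 4 is altered. Going by the values given here, compounds 2 and 3 carry a group at that amine nitrogen different from the one in compound 1, but their values against compound 1 are all within the scatter. Among the compounds with values here, the change in compound 4 therefore has no measured precedent, and no step beyond the scatter is expected in either direction.

Compound 4 is estimated at 9500 nM in this assay, with a range from 3000 nM to 30000 nM. This estimate means a step of no change at the digits printed from compound 1 to compound 4 (within the scatter), expected to stay within the scatter.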

Compound 4, half-maximal inhibitory concentration: 35200 nM
Beside the measured number, compound 4's estimate is 3.7-fold (0.57 log units) below it; the whole stated range lies below it.
By their numbers in this assay, from the lowest: compounds 1, 2 and 3 (each within the scatter of the next); then compound 4.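

In this assay, the swap of 2-cyanobenzyl for the group of 11 heavy atoms on the amine nitrogen in a ring gives a 3.7-fold higher number from compound 1 to compound 4 (0.57 log units; beyond the scatter). This is the first step beyond the scatter among the compounds shown, and it shows that the number responds to a change at this position, whereas the only earlier step, at a carbonyl carbon, stayed within the scatter. No measurement shown accounts for the step.

Because the entering group differs from 2-cyanobenzyl in several features at once, this single pair does not show which of them goes with the higher number. It also leaves open how a plain benzyl group, a small alkyl chain or an acetyl group on the same nitrogen would compare with compound 1.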